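Phenoxy removal from compound 3 on the sulfonamide ring

The source may hold more compounds than are shown below. What is called first, only, known or untested is meant among the compounds shown, and "the series" means these compounds.

Three compounds share one core and differ only in the ring on the sulfonamide nitrogen. Compound 1 `COc1ccc(NS(=O)(=O)c2ccc(N3CCNC3=O)cc2)cc1` gives 580 nM in a functional assay on M21 cells (Homo sapiens) for antiproliferative activity, read by sulforhodamine B assay, with a stated time of 48 h; a higher number here means a weaker inhibitor, a lower number a stronger inhibitor. Compound 2 `O=C1NCCN1c1ccc(S(=O)(=O)Nc2ccc(F)c(F)c2)cc1` gives 220 nM in this assay. Compound 3 `O=C1NCCN1c1ccc(S(=O)(=O)Nc2cccc(Oc3ccccc3)c2)cc1` gives 83 nM in this assay and stands lowest of the three, beyond the scatter from both others, so among these numbers it is the strongest inhibitor.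

Compound 4 `O=C1NCCN1c1ccc(S(=O)(=O)Nc2ccccc2)cc1` is not yet measured. It differs from compound 3 in one place: hydrogen in place of phenoxy on an aromatic carbon. Within the data shown here, the only measured single-point step, a 2.6-fold lower number from compound 1 to compound 2 (0.42 log units; beyond the scatter), also exchanges the group on the ring at the sulfonamide nitrogen, and it was modest. Among the measured compounds shown here, no measured step removes a group to leave hydrogen, so the direction rests on the spread of the three values: compound 3, carrying the largest group on that ring, gives 83 nM, while compounds 1 and 2 with smaller groups sit higher. For the measured compounds named here, a shift toward a higher number is therefore expected for compound 4, probably larger than the one measured step, a 4.8-fold higher number from compound 3 to compound 4 (0.68 log units; beyond the scatter). Compound 4 is estimated at 400 nM in this assay, with a range from 120 nM to 1400 nM.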

Compound 4, half-maximal inhibitory concentration: 200 nM
For compound 4 the middle estimate is 2.0-fold (0.30 log units) above the measured one, within the range that was stated.
By their numbers in this assay, from the lowest: compound 3; then compounds 4 and 2 (each within the scatter of the next); then compound 1.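

In this assay, taking phenoxy off the ring costs only a modest step (a 2.4-fold higher number from compound 3 to compound 4 (0.38 log units; beyond the scatter)), so compound 3's phenoxy group is not needed for a value in this range, and the plain phenyl ring of compound 4 keeps most of the activity. Against that same phenyl ring, the 3,4-difluorophenyl ring of compound 2 shows no readable difference (a 1.1-fold lower number from compound 2 to compound 4 (0.04 log units; within the scatter)), while hydrogen in place of methoxy gives a lower number (a 2.9-fold lower number from compound 1 to compound 4 (0.46 log units; beyond the scatter)). Compound 4 therefore changes the earlier picture of larger groups on this ring giving lower numbers: compound 3 alone fits that picture, and compound 1, with its methoxy group, goes against it.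

Nothing at hand bears on why these steps have the sizes they do. Going by these compounds, it remains open whether the lower number of compound 3 needs the second aromatic ring itself or would also appear with a benzyloxy group, a simple ethoxy chain, an amine or a carboxylic acid on the same carbon.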